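Two Aryl Replacements on a Shared Core

This account rests on a few compounds, and the source may have more. Where it says the series, first, only, none or still open, it means among the compounds named here.

Compound 1 `COc1ccc(/C=N/NC(=O)CSc2nnc(-c3ccncc3)o2)cc1` gives 17600 nM in a functional assay on MCF7 cells (Homo sapiens) for cytotoxicity, read by MTT assay, with a stated time of 48 h; on this read-out lower numbers stand for stronger inhibition and higher numbers for weaker inhibition.
Compound 2 `O=C(CSc1nnc(-c2ccncc2)o1)N/N=C/c1ccccc1[N+](=O)[O-]` gives 35600 nM in this assay.

Compound 2 stands highest of the two numbers in this assay; its nearest neighbour is compound 1. Within the data shown here, the single measured step, a 2.0-fold higher number from compound 1 to compound 2 (0.31 log units; beyond the scatter), arose from swapping the aryl group on the carbon with a double bond to nitrogen. Compound 3 `O=C(CSc1nnc(-c2ccncc2)o1)N/N=C/c1ccc(Cl)cc1Cl` differs from compound 2 by 2,4-dichlorophenyl in place of 2-nitrophenyl on a carbon with a double bond to nitrogen. This change is not the one measured, so only its scale offers guidance: a step of modest size in either direction is expected, a 1.4-fold lower number from compound 2 to compound 3 (0.15 log units; within the scatter). Compound 3 is therefore estimated at 25000 nM, within 9000 nM to 70000 nM.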

Compound 3, half-maximal inhibitory concentration: 27900 nM
The estimate for compound 3 lay 1.1-fold (0.05 log units) below the measured number; the range from low to high includes it.
By their numbers in this assay, from the lowest: compounds 1, 3 and 2 (each within the scatter of the next, the first and the last beyond it).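

In this assay, 2,4-dichlorophenyl on a carbon with a double bond to nitrogen gives a 1.3-fold lower number from compound 2 to compound 3 (0.11 log units; within the scatter) and, against the other aryl group, a 1.6-fold higher number from compound 1 to compound 3 (0.20 log units; within the scatter). Among these compounds, compound 3 is thus set apart from neither earlier compound, and the only printed difference beyond the scatter at this position remains the one between compound 1 and compound 2. No supporting data bear on why these aryl groups compare as they do. Still open, from the compounds shown here alone, is whether an amine or a carboxylic acid on the aryl group, or a cyclohexyl group in its place, would shift the number further. Changes elsewhere on the shared core also remain open.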